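The compounds below may be only part of what the source reports. "The series", "measured", "known", "first", "only" and "open" are said of these compounds alone.

Compound 1 `CCC(C)c1cc(C2C(C#N)=C(N)OC3=C2C(=O)CC(C)(C)C3)cc2cc(-c3ccc(OC)cc3)c(=O)oc12` gives 26.9% in a functional assay on the whole organism (strain Swiss albino) with Mus musculus as the target, in the forced swim test, with a stated time of 5 min, at a dose of 0.5 mg/kg by the intraperitoneal route; a higher number here means more inhibition at the dose given (going by the name of the read-out), a lower number less inhibition. Compound 2 `CCC(C)c1cc(C2C(C#N)=C(N)OC3=C2C(=O)CC(C)(C)C3)cc2cc(-c3ccc(OC)c(OC)c3)c(=O)oc12` gives 57.4%. Compound 3 `CCC(C)c1cc(C2C(C#N)=C(N)OC3=C2C(=O)CC(C)(C)C3)cc2cc(-c3cc(OC)c(OC)c(OC)c3)c(=O)oc12` gives 28.2%.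

Compound 2 stands highest of the three in this assay: the step of a number 30.5 percentage points higher from compound 1 to compound 2 (beyond the scatter) and the step of a number 29.2 percentage points lower from compound 2 to compound 3 (beyond the scatter) both lie beyond the scatter, while compound 1 and compound 3 sit within the scatter of each other, as a number 1.3 percentage points higher from compound 1 to compound 3 (within the scatter) shows.

Compound 4 `COc1ccc(-c2cc3cc(C4C(C#N)=C(N)OC5=C4C(=O)CC(C)(C)C5)cc(C(C)(C)C)c3oc2=O)cc1OC` differs from compound 2 by tert-butyl in place of sec-butyl on an aromatic carbon. Going by the values given here, none of the measured steps touches this group; all three vary only the methoxy pattern on the phenyl ring, so no measured step bears directly on the change. On that basis compound 4 is expected to stay close to compound 2, with no step beyond the scatter in this assay, the expected shift being a number 5.4 percentage points lower from compound 2 to compound 4 (within the scatter). Compound 4 is estimated at 52%, with a range from 32% to 68%.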

Compound 4, a percentage reported as inhibition, in the whole organism at one dose (the size of the read-out at that dose, not a potency): 22.5%
Compound 4: middle estimate off by 29.5 percentage points, on the high side, outside the stated range (below it).
By their numbers in this assay, from the lowest: compounds 4, 1 and 3 (each within the scatter of the next); then compound 2.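

In this assay, replacing sec-butyl with tert-butyl, two groups with the same atoms joined differently, gives a number 34.9 percentage points lower from compound 2 to compound 4 (beyond the scatter). Going by these compounds alone, this shows that the position on the shared core left unchanged by the earlier compounds also bears on the read-out, and that rearranging the butyl chain alone is enough to matter. Nothing available accounts for this change.

The compounds shown leave open how an isopropyl group, a methoxy group or a longer chain such as n-pentyl would read at this position. They also leave open whether tert-butyl would give a similar step alongside the methoxy patterns of compound 1 and compound 3.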